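Stretching the ether chain on a hydroxyphenyl chromone core

The source may report more compounds than this note shows. Statements on the series, on what has been measured and on what is new or still open speak of the compounds shown alone.

Measured compounds:
compound 1, `CCOc1ccc2c(=O)c(-c3ccc(O)cc3)coc2c1`: 64.8%
compound 2, `O=c1c(-c2ccc(O)cc2)coc2cc(CC3OC(CO)C(O)C(O)C3O)ccc12`: 0%

Of the compounds shown here, two have been tested in a functional assay on mitochondria (Cricetulus griseus) for inhibition of Monoamine oxidase (Homo sapiens), tested at 0.3 uM; a lower number here means a weaker effect, a higher number a stronger effect of the compound at the concentration tested. Compound 1 gives 64.8%. Compound 2, which carries a sugar-derived chain instead of an ethoxy group, gives 0%. On these two numbers compound 1 stands highest, and its distance to compound 2 lies well beyond the usual scatter, so the shared core with a small ether group on the ring clearly does better here than the same core with the large, hydroxyl-rich substituent.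

The unmeasured compound 3, `O=c1c(-c2ccc(O)cc2)coc2cc(OCCCCCCBr)ccc12`, keeps everything of compound 1 and changes only one place: 4-bromobutyl in place of hydrogen on a saturated chain carbon, two bonds along the chain from an oxygen on an aromatic ring. Read from one bond further out, this is ethoxy turning into (6-bromohexyl)oxy. Among the measured compounds shown here, no measured pair shows what this kind of change does, so the expectation rests on compound 1 alone. A modest step upward, about at the edge of the scatter, is expected, as a number 10.2 percentage points higher from compound 1 to compound 3 (beyond the scatter). Compound 3 is therefore estimated at 75%, with a plausible range from 45% to 95%.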

Compound 3, a percentage reported as inhibition, at one concentration (the size of the read-out at that concentration, not a potency): 47.2%
Estimate against measurement, compound 3: 27.8 percentage points above, within the range that was stated.
By their numbers in this assay, from the lowest: compound 2; then compound 3; then compound 1.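

Compound 3 shows that this position, a saturated chain carbon two bonds along the chain from an oxygen on an aromatic ring, can carry a much longer chain without the effect disappearing: this assay still reaches 47.2% for compound 3. Adding the 4-bromobutyl group does cost something, though, with a number 17.6 percentage points lower from compound 1 to compound 3 (beyond the scatter), so the small ethoxy group of compound 1 remains the better of these two ether groups at this concentration. Nothing measured here says what lies behind this step.

Because length and bromine enter together in a single change, the two compounds cannot show which of them accounts for the drop; a plain hexyl ether without bromine would separate the chain from its end atom, and a shorter 4-bromobutyl ether would show how the number moves with length. As far as these compounds go, it also stays open whether a different group at the end of the chain, such as an amine or a carboxylic acid, would raise or lower the number compared with bromine.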